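All at the limit: aryl swap on the azole nitrogen

This account rests on a few compounds, and the source may have more. Where it says the series, first, only, none or still open, it means among the compounds named here.

Compound 1 `CCOc1ccc(-n2nncc2CN2C(=O)C3(C(C#N)=C(N)Oc4c3c3nc5ccccc5nc3c3ccccc43)c3ccccc32)cc1` gives, in a functional assay on HepG2 cells (Homo sapiens) for antiproliferative activity, read by MTT assay, with a stated time of 48 h (a lower number here means a stronger inhibitor, a higher number a weaker inhibitor), > 50000 nM, a limit of the assay rather than a number.
Compound 2 `N#CC1=C(N)Oc2c(N)cc3nc4ccccc4nc3c2C12C(=O)N(Cc1cnnn1-c1ccc(F)cc1)c1ccccc12` gives in this assay > 50000 nM, again a limit.
Compound 3 `CCc1cccc(C)c1-n1nncc1CN1C(=O)C2(C(C#N)=C(N)Oc3c(N)cc4nc5ccccc5nc4c32)c2ccccc21` gives in this assay > 50000 nM, also a limit.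

Compound 3 therefore stands at the limit of this assay, and the two other values shown for the series are limits as well. For the measured compounds named here, the one single-point step recorded, a step that the two limits leave unreadable from compound 2 to compound 3, is unreadable, since both ends sit at the limit. The step from compound 3 to compound 4 `N#CC1=C(N)Oc2c(N)cc3nc4ccccc4nc3c2C12C(=O)N(Cc1cnnn1-c1c(Cl)cc(Cl)cc1Cl)c1ccccc12` replaces (2,4,6-trichlorophenyl in place of 2-ethyl-6-methylphenyl on an aromatic nitrogen). Going by the values given here, no measured step bears on it in a readable way; the only evidence is the limit of > 50000 nM in this assay, at which 3 of the 3 values shown sit. Because the limit of > 50000 nM in this assay, at which 3 of the 3 values shown sit, holds for every aryl group tried on this nitrogen, no move beyond the scatter is expected in this assay. Compound 4 is expected to give 100000 nM, in the range 40000 nM to 300000 nM, most likely reported once more as a limit only. The step that the limit leaves unreadable from compound 3 to compound 4 is the estimated consequence.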

Compound 4, half-maximal inhibitory concentration: 37800 nM
Estimate against measurement, compound 4: 2.6-fold (0.42 log units) above, outside the stated range (below it).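

In this assay, for the compounds shown here, compound 4 gives 37800 nM as a number and not a limit, the only such value shown for an aryl group on this nitrogen. The change to 2,4,6-trichlorophenyl gives an at least 1.3-fold lower number from compound 3 to compound 4 (0.12 log units; that floor lies within the scatter) and also an at least 1.3-fold lower number from compound 2 to compound 4 (0.12 log units; that floor lies within the scatter) as its readable steps; both floors stay within the scatter, so no real gain can be claimed and the true size of either step stays unfixed. The position can therefore return a measurable value, while the step between the two limits remains unreadable.

Going by these compounds, whether an aminophenyl, a carboxyphenyl or a cyclohexyl group on this nitrogen would carry the value clearly beyond the scatter stays open. On these data alone, it also stays open whether all of the chlorine atoms are needed for a measurable value.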